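A few compounds are considered here, and "the series" means these few. Any claim that something is new, unique, unknown or untested is made for them only; others in the source may bear on it.

In a functional assay on LOX IMVI cells (Homo sapiens) for cytotoxicity, read by MTT assay, with a stated time of 24 h (a higher number here means a weaker inhibitor, a lower number a stronger inhibitor), compound 3 (`O=S(=O)(NCCCNc1nccc(-c2[nH]c(-c3ccccc3)nc2-c2ccc(Cl)c(O)c2)n1)c1ccc(F)cc1`) gives 2300 nM and compound 1 (`COc1cc(-c2nc(-c3ccccc3)[nH]c2-c2ccnc(NCCCNS(=O)(=O)c3ccc(F)cc3)n2)ccc1F`) gives 3960 nM. Among the measured compounds shown here, the one measured step, a 1.7-fold lower number from compound 1 to compound 3 (0.24 log units; within the scatter), lies at another place in the molecule. Compound 2 (`COc1cc(-c2nc(-c3ccccc3)[nH]c2-c2ccnc(NCCCNS(=O)(=O)c3cccc4ccccc34)n2)ccc1Cl`) gives 13500 nM, beyond the scatter above both. Compound 4 (`O=S(=O)(NCCCNc1nccc(-c2[nH]c(-c3ccccc3)nc2-c2ccc(Cl)c(O)c2)n1)c1cccc2ccccc12`) differs from compound 3 by naphthalen-1-yl in place of 4-fluorophenyl on a sulfonyl sulfur, with naphthalen-1-yl in place of 4-fluorophenyl on a sulfonyl sulfur. For the measured compounds named here, no measured step isolates this change. Compound 2 also carries naphthalen-1-yl, but it differs from compound 1 in a second place, so compound 2 at 13500 nM is only indirect support for a moderate rise. The expected change is a 3.3-fold higher number from compound 3 to compound 4 (0.51 log units; beyond the scatter), towards a higher number. For compound 4 the estimated value is 7500 nM, with an expected range of 3000 nM to 18000 nM.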

Compound 4, half-maximal inhibitory concentration: 7720 nM
For compound 4 the middle estimate is 1.0-fold (0.01 log units) below the measured one; low and high end bracket the measured number.
By their numbers in this assay, from the lowest: compounds 3, 1, 4 and 2 (each within the scatter of the next, the first and the last beyond it).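

In this assay the position on the sulfonyl sulfur now has its own measured change: naphthalen-1-yl in place of 4-fluorophenyl gives a 3.4-fold higher number from compound 3 to compound 4 (0.53 log units; beyond the scatter), with the 4-chloro-3-hydroxyphenyl group held fixed. Among the naphthalen-1-yl compounds, hydrogen in place of methyl on an oxygen on an aromatic ring gives a 1.7-fold lower number from compound 2 to compound 4 (0.24 log units; within the scatter), so only the sulfonyl change reads beyond the scatter. Nothing available accounts for this rise. Still open, going by these compounds, is how a benzyl group or a simple methyl group on the sulfonyl sulfur would read. Also open, on these data alone, is whether a carboxylic acid on the aromatic ring there would keep or reverse the step.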